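Adding a second hydroxy to the chain of compound 2

The source may hold more compounds than are shown below. What is called first, only, known or untested is meant among the compounds shown, and "the series" means these compounds.

Compound 1 `Nc1ncnc2c1nc(Br)n2CCCO` gives 1000 nM in an assay on CHO cells for displacement of a labelled ligand from adenosine receptor A1 (Homo sapiens); a lower number here means a stronger inhibitor, a higher number a weaker inhibitor.
Compound 2 `CC(O)Cn1c(Br)nc2c(N)ncnc21` gives 2900 nM in this assay.

Both compounds share the same core and differ only in the short chain on the ring nitrogen. The measured step of a 2.9-fold higher number from compound 1 to compound 2 (0.46 log units; beyond the scatter) shows that moving the hydroxy along that chain is not neutral. Compound 2 therefore stands at the highest number of the two, with compound 1 as its nearest neighbour.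

Compound 3 `Nc1ncnc2c1nc(Br)n2CC(O)CO` keeps the chain of compound 2 and introduces one further change: hydroxy in place of hydrogen on a saturated chain carbon, two bonds along the chain from an oxygen on a saturated carbon. Going by the values given here, no measured step covers the addition of a hydroxy of this kind; the only step available, from compound 1 to compound 2, concerns where one hydroxy sits rather than how many there are, so it gives only a loose guide. The chain of compound 3 ends as in compound 1 and also carries the hydroxy of compound 2, so a number somewhere near those two values, with wide uncertainty, is expected, a 1.5-fold lower number from compound 2 to compound 3 (0.16 log units; within the scatter). The estimate for compound 3 in this assay is 2000 nM, within 700 nM to 6000 nM.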

Compound 3, inhibition constant: 16000 nM
Beside the measured number, compound 3's estimate is 8.0-fold (0.90 log units) below it; the whole stated range lies below it.
By their numbers in this assay, from the lowest: compound 1; then compound 2; then compound 3.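

Compound 1 and compound 2 showed only that moving one hydroxy along the chain changes the number, whereas compound 3 shows what a second hydroxy on that chain does. Adding it to the 2-hydroxypropyl chain to give the 2,3-dihydroxypropyl chain produces a 5.5-fold higher number from compound 2 to compound 3 (0.74 log units; beyond the scatter) and the same addition, read on a saturated chain carbon bound to two saturated chain carbons, produces a 16-fold higher number from compound 1 to compound 3 (1.20 log units; beyond the scatter) in this assay so compound 3 is the weakest of the three whichever single-hydroxy chain it is compared with. Nothing available explains why this second hydroxy goes with such a rise.

The compounds shown leave open whether the rise belongs to the hydroxy itself or would follow any group on that carbon, such as a methoxy, an amine or a fluorine. They also leave open how a plain propyl chain with no hydroxy at all, or a longer chain that keeps both hydroxy groups, would compare with these three on the same shared core.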